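A Basic Side Chain Shortened on Two Related Cores

This account rests on a few compounds, and the source may have more. Where it says the series, first, only, none or still open, it means among the compounds named here.

compound 1 `CCN(CC)CCCn1c(N)c(-c2nc3ccccc3n2C)c2nc(C#N)c(C#N)nc21`: 10700 nM
compound 2 `CN(C)CCCCn1c(N)c(-c2nc3ccccc3n2C)c2nc(C#N)c(C#N)nc21`: 6150 nM
compound 3 `CCN(CC)CCn1c(N)c(-c2nc3cc(Cl)ccc3[nH]2)c2nc(C#N)c(C#N)nc21`: > 50000 nM

In a functional assay on A549 cells (Homo sapiens) for antiproliferative activity, read by MTT assay, with a stated time of 48 h (on this read-out higher numbers stand for weaker inhibition and lower numbers for stronger inhibition), compound 1 gives 10700 nM and compound 2 gives 6150 nM. The change between them is (dimethylamino)methyl in place of diethylamino on a saturated chain carbon, three bonds along the chain from an aromatic nitrogen, and its size is a 1.7-fold lower number from compound 1 to compound 2 (0.24 log units; within the scatter). Compound 3 carries a different core; how that core differs from the core of compound 1 is not broken down here. For compound 3 the result is only a limit of the assay, > 50000 nM, namely (the limit of > 50000 nM in this assay, at which 1 of the 3 values shown sits).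

Compound 4 `CN(C)CCCn1c(N)c(-c2nc3cc(Cl)ccc3[nH]2)c2nc(C#N)c(C#N)nc21` comes from compound 3 by (dimethylamino)methyl in place of diethylamino on a saturated chain carbon, two bonds along the chain from an aromatic nitrogen. This is the same kind of change as from compound 1 to compound 2, though here the place is two bonds along the chain from the aromatic nitrogen rather than three. Because the earlier step of a 1.7-fold lower number from compound 1 to compound 2 (0.24 log units; within the scatter) stayed within the scatter, the expected step from compound 3 to compound 4 is an at least 1.1-fold lower number from compound 3 to compound 4 (0.04 log units; that floor lies within the scatter). Compound 4 is estimated at 45000 nM, and it may again be reported only as a limit.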

Compound 4, half-maximal inhibitory concentration: > 50000 nM
Compound 4 ended at the assay's limit; the forecaster's own chance of this, stated with the estimate: 60%; middle value at least 1.1-fold (0.04 log units) away from the limit.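

No step from compound 3 to compound 4 can be read, because both compounds sit at a limit of this assay: the limit of > 50000 nM in this assay, at which 2 of the 4 values shown sit.

The compounds shown leave open whether this side-chain change alters activity at all on the core of compound 3.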